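The compounds below may be only part of what the source reports. "The series", "measured", "known", "first", "only" and "open" are said of these compounds alone.

Working notes on the series. The shared core is carried by compound 2 `CC(C)c1cccc(C(C)C)c1NC(=O)NCC1(c2ccc(C(F)(F)F)cc2)CCCC1`, compound 1 `CC(C)c1cccc(C(C)C)c1NC(=O)NCC1(c2ccc(OCc3ccccc3)cc2)CCCC1` and compound 3 `CC(C)c1cccc(C(C)C)c1NC(=O)NCC1(c2cccc(N)c2)CCCC1`. In an assay on microsomes for inhibition of acyl-CoA:cholesterol acyltransferase (Oryctolagus cuniculus) (on this read-out lower numbers stand for stronger inhibition and higher numbers for weaker inhibition), compound 2 gives 66 nM, the highest of the three numbers. Compound 1 gives 34 nM, and compound 3 gives 21 nM. The step of a 1.9-fold higher number from compound 1 to compound 2 (0.29 log units; within the scatter) lies within the scatter, whereas the step of a 3.1-fold lower number from compound 2 to compound 3 (0.50 log units; beyond the scatter) lies beyond it and is modest. Compound 4 `Cc1ccc(C2(CNC(=O)Nc3c(C(C)C)cccc3C(C)C)CCCC2)c(C)c1` is not yet measured; it differs from compound 2 as follows: 2,4-dimethylphenyl in place of 4-(trifluoromethyl)phenyl on a saturated ring carbon. Both measured steps bear on this change, since each alters the aromatic group that sits on a saturated ring carbon, and each stays small: one inside the scatter, one only modestly beyond it. A further exchange of this group is therefore expected to move the number little, with no direction clearly favoured. Compound 4 is estimated at 40 nM in this assay, with a range from 15 nM to 110 nM. The expected step is a 1.7-fold lower number from compound 2 to compound 4 (0.22 log units; within the scatter), within the scatter.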

Compound 4, half-maximal inhibitory concentration: 50 nM
Compound 4: middle estimate off by 1.3-fold (0.10 log units), on the low side; the measured number falls inside the stated range.
By their numbers in this assay, from the lowest: compounds 3, 1, 4 and 2 (each within the scatter of the next, the first and the last beyond it).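

In this assay, the step of a 1.3-fold lower number from compound 2 to compound 4 (0.12 log units; within the scatter) lies within the scatter, so 2,4-dimethylphenyl, which carries no fluorine, and 4-(trifluoromethyl)phenyl cannot be told apart on this saturated ring carbon. The trifluoromethyl group is therefore not required for a number of this size, and the aromatic group here tolerates two methyl groups. The step of a 2.4-fold higher number from compound 3 to compound 4 (0.38 log units; beyond the scatter) lies beyond the scatter but is modest, so 3-aminophenyl keeps only a small margin over 2,4-dimethylphenyl, and no measurement on hand bears on the reason for that margin.

On these data alone, whether a carboxylic acid or a longer alkyl chain on the aromatic ring would keep the number in this range remains open. Also open, as far as these compounds go, is how an unsubstituted phenyl group would compare, which leaves the contribution of the amino group in compound 3 undefined.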